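Chloro-Methoxyphenyl Replaces Dichlorophenyl on the Shared Core

The source may report more compounds than this note shows. Statements on the series, on what has been measured and on what is new or still open speak of the compounds shown alone.

Of the compounds shown here, three built on one shared core have been measured. Compound 1 `CCCS(=O)(=O)Nc1ccc(F)c(C(=O)c2n[nH]c3ncc(-c4ccccc4OC)cc23)c1F` gives 1.9% in an assay for binding affinity to dual specificity mitogen-activated protein kinase kinase 4 (Homo sapiens), read by KINOMEscan, tested at 100 nM; a higher number here means a weaker effect of the compound at the concentration tested, a lower number a stronger effect. Compound 2 `CCCS(=O)(=O)Nc1ccc(F)c(C(=O)c2n[nH]c3ncc(-c4cccc(O)c4)cc23)c1F` gives 2.2% in this assay, and compound 3 `CCCS(=O)(=O)Nc1ccc(F)c(C(=O)c2n[nH]c3ncc(-c4ccc(Cl)c(Cl)c4)cc23)c1F` gives 45% in this assay. Compound 3 thus stands highest of the three numbers; its nearest neighbour is compound 2 and the furthest is compound 1, and both lie beyond the scatter from it. Between compound 1 and compound 2 the step was a number 0.3 percentage points higher from compound 1 to compound 2 (within the scatter).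

Compound 4 `CCCS(=O)(=O)Nc1ccc(F)c(C(=O)c2n[nH]c3ncc(-c4ccc(OC)cc4Cl)cc23)c1F` has not yet been measured. It differs from compound 3 as follows: 2-chloro-4-methoxyphenyl in place of 3,4-dichlorophenyl on an aromatic carbon. For the measured compounds named here, two measured steps bear on this change, since each of them put 3,4-dichlorophenyl in place of a ring carrying an oxygen: a number 43.1 percentage points higher from compound 1 to compound 3 (beyond the scatter) and a number 42.8 percentage points higher from compound 2 to compound 3 (beyond the scatter). Compound 4 reverses part of that exchange, keeping one chlorine while bringing a methoxy back onto the ring. A step in this assay in the opposite direction is therefore expected, sizeable though perhaps not a full return, because compound 1 with its 2-methoxyphenyl gave 1.9%. The step from compound 3 to compound 4 is expected to be a number 30 percentage points lower from compound 3 to compound 4 (beyond the scatter). Compound 4 is expected to give 15%, within a range from 3% to 40%.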

Compound 4, a percentage reported as activity, at one concentration (the size of the read-out at that concentration, not a potency): 5.3%
Estimate against measurement, compound 4: 9.7 percentage points above; measured number inside the range.
By their numbers in this assay, from the lowest: compounds 1, 2 and 4 (each within the scatter of the next); then compound 3.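

In this assay, the exchange of 3,4-dichlorophenyl for 2-chloro-4-methoxyphenyl brought a number 39.7 percentage points lower from compound 3 to compound 4 (beyond the scatter), which shows that a chlorine on the ring at this position does not by itself go with the high number seen for compound 3. The new ring also stands level with both earlier oxygen-bearing rings, with a number 3.1 percentage points higher from compound 2 to compound 4 (within the scatter) and a number 3.4 percentage points higher from compound 1 to compound 4 (within the scatter), so among these four compounds all three rings with an oxygen give low numbers, whether or not they also carry a chlorine, and compound 3, the only ring without oxygen, is the sole high one, with no compound going against this pattern. No measurement shown here explains why the number falls with this change.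

The two rings differ at once in the number of chlorines, in where the chlorine sits and in the presence of the methoxy, so the compounds shown do not separate these contributions. From the compounds shown here alone, it also remains open how this position would respond to a phenyl ring carrying a single chlorine and no oxygen, or to one carrying an amine or a carboxylic acid.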